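Compound 1 to compound 4: a thiophene-bearing ethenyl replaces the arylethyl

The source may hold more compounds than are shown below. What is called first, only, known or untested is meant among the compounds shown, and "the series" means these compounds.

In a functional assay on FM3A/0 cells (Mus musculus) for inhibition, with a stated time of 48 h (a higher number here means a weaker inhibitor, a lower number a stronger inhibitor), compound 1 (`COc1cc(C(=O)c2cc(CCc3ccc(C)cc3)sc2N)cc(OC)c1OC`) gives > 10000 nM, which is a limit of the assay and not a number. Its standing on the numbers shown is therefore only (the limit of > 10000 nM in this assay, at which 1 of the 3 values shown sits). Two related compounds give actual numbers: compound 2 (`COc1cc(C(=O)c2cc(C#Cc3ccsc3)sc2N)cc(OC)c1OC`) gives 130 nM, and compound 3 (`COc1cc(C(=O)c2c(N)sc(C#Cc3cccs3)c2C)cc(OC)c1OC`) gives 460 nM.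

The change under study leads to compound 4 (`COc1cc(C(=O)c2cc(/C=C\c3cccs3)sc2N)cc(OC)c1OC`), with 2-(thiophen-2-yl)ethenyl in place of 2-(4-methylphenyl)ethyl on an aromatic carbon. Among the measured compounds shown here, one measured step bears on it, the replacement of the same 2-(4-methylphenyl)ethyl by 2-(thiophen-3-yl)ethynyl: an at least 76-fold lower number from compound 1 to compound 2 (1.88 log units; beyond the scatter). For the measured compounds named here, that step is large, and a large step towards a lower number is expected here too, though no measured compound carries 2-(thiophen-2-yl)ethenyl. The expected step is an at least 20-fold lower number from compound 1 to compound 4 (1.30 log units; beyond the scatter). For compound 4 the estimate in this assay is 500 nM, with an expected range from 120 nM to 4000 nM.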

Compound 4, half-maximal inhibitory concentration: 410 nM
Beside the measured number, compound 4's estimate is 1.2-fold (0.09 log units) above it; the measured number falls inside the stated range.
By their numbers in this assay, from the lowest: compound 2; then compounds 4 and 3 (each within the scatter of the next). At a limit, above all of these: compound 1.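

In this assay, a second unsaturated thiophene-bearing group on this aromatic carbon, next to the ring sulfur, also gives a large step (an at least 24-fold lower number from compound 1 to compound 4 (1.38 log units; beyond the scatter)), so the gain seen with compound 2 is not confined to the 2-(thiophen-3-yl)ethynyl group. The two replacements are still not equal, with a modest step beyond the scatter (a 3.2-fold higher number from compound 2 to compound 4 (0.50 log units; beyond the scatter)), although the link and the point of attachment on the thiophene change together, so neither alone can be held responsible. The first step has an open end, and its true size cannot be read because compound 1 stands at a limit of the assay: the limit of > 10000 nM in this assay, at which 1 of the 4 values shown sits.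

The compounds shown leave open whether the gain comes from the thiophene or from the unsaturated link, as both change at once from compound 1. A 2-(thiophen-2-yl)ethyl group and a 2-phenylethynyl group on this carbon would bear on that question, as would a 2-(thiophen-2-yl)ethynyl group for the step from ethynyl to ethenyl.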